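This account rests on a few compounds, and the source may have more. Where it says the series, first, only, none or still open, it means among the compounds named here.

- compound 1 `CC(O)(CSc1cccc(OC(F)(F)F)c1)C(=O)Nc1cc(C(F)(F)F)cc(C(F)(F)F)c1`: 9610 nM
- compound 2 `CC(O)(COc1cc(C(F)(F)F)cc(C(F)(F)F)c1)C(=O)Nc1ccc(C#N)cc1C(F)(F)F`: 8050 nM

In a functional assay on DU-145 cells (Homo sapiens) for antiproliferative activity, read by fluorescence and propidium iodide staining, with a stated time of 96 h (a lower number here means a stronger inhibitor, a higher number a weaker inhibitor), compound 1 gives 9610 nM and compound 2 gives 8050 nM. These two values lie within the usual scatter of repeated measurements, so they cannot be ranked, and compound 2 stands level with compound 1. The next compound, compound 3 `CC(O)(COc1cc(C(F)(F)F)cc(C(F)(F)F)c1)C(=O)Nc1ccc([N+](=O)[O-])cc1C(F)(F)F`, differs from compound 2 in a single place: nitro in place of cyano on an aromatic carbon. Among the compounds with values here, no measured pair here shows what this swap does. With only compound 2 at 8050 nM as a guide, no shift beyond the scatter is expected in this assay, in either direction. The expected step is small, a 1.1-fold lower number from compound 2 to compound 3 (0.03 log units; within the scatter). The estimated value for compound 3 is 7500 nM, with an expected range of 2500 nM to 20000 nM.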

Compound 3, half-maximal inhibitory concentration: 11600 nM
Estimate against measurement, compound 3: 1.5-fold (0.19 log units) below; the measured number falls inside the stated range.
By their numbers in this assay, from the lowest: compounds 2, 1 and 3 (each within the scatter of the next).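

In this assay, putting nitro in place of cyano on this aromatic carbon gives a 1.4-fold higher number from compound 2 to compound 3 (0.16 log units; within the scatter) and so cannot rank the two compounds. Within the data shown here, this is the first direct comparison at this position, which is para to a large group and meta to a trifluoromethyl group, and it shows that the two groups cannot be told apart here, even though they differ in their atoms and bonds. No measurement available here bears on the reason for this result.

This single pair says nothing about how very different groups would read on the same aromatic carbon, such as an amine or a carboxylic acid. It also leaves open whether nitro and cyano would still read alike on a different core.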